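The source may report more compounds than this note shows. Statements on the series, on what has been measured and on what is new or still open speak of the compounds shown alone.

Measured so far:
compound 1 `COc1ccc(CN2CCC(CCNC(=O)/C=C/c3cc(C(C)(C)C)c(O)c(C(C)(C)C)c3)CC2)cc1` — 6700 nM
compound 2 `Cc1ccccc1CN1CCC(CCNC(=O)/C=C/c2cc(C(C)(C)C)c(O)c(C(C)(C)C)c2)CC1` — 7200 nM
compound 3 `CC(C)(C)c1cc(/C=C/C(=O)NCCC2CCN(Cc3cccc(F)c3)CC2)cc(C(C)(C)C)c1O` — 6500 nM

All three values come from an assay on isolated protein for inhibition of Amine oxidase [flavin-containing] B (Homo sapiens), read by fluorescence, with stated times of 15 min and 20 min; on this read-out lower numbers stand for stronger inhibition and higher numbers for weaker inhibition. The series keeps one shared core and varies only the aryl group on the saturated chain carbon bound to the amine nitrogen in the ring. Compound 3 sits together with compound 1 and compound 2: the step from compound 1 to compound 3 is a 1.0-fold lower number from compound 1 to compound 3 (0.01 log units; within the scatter) and the step from compound 2 to compound 3 is a 1.1-fold lower number from compound 2 to compound 3 (0.04 log units; within the scatter), so no separation among the three is established. The step between the other two, a 1.1-fold higher number from compound 1 to compound 2 (0.03 log units; within the scatter), is likewise flat.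

Compound 4 `CC(C)(C)c1cc(/C=C/C(=O)NCCC2CCN(Cc3ccc(F)cc3F)CC2)cc(C(C)(C)C)c1O` continues the same variation: 2,4-difluorophenyl in place of 3-fluorophenyl on a saturated chain carbon bound to an amine nitrogen in a ring. The bearing steps are the three aryl swaps already seen, none of which moved this assay beyond the scatter. A second fluorine on the same ring gives no reason in these data for a different outcome, so for compound 4 the expected step in this assay is no change at the digits printed from compound 3 to compound 4 (within the scatter), that is, no change beyond the scatter. Compound 4 is therefore estimated at 6500 nM, with a range from 3000 nM to 14000 nM.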

Compound 4, half-maximal inhibitory concentration: 12500 nM
For compound 4 the middle estimate is 1.9-fold (0.28 log units) below the measured one, within the range that was stated.
By their numbers in this assay, from the lowest: compounds 3, 1, 2 and 4 (each within the scatter of the next).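

Across this assay, the steps of a 1.9-fold higher number from compound 3 to compound 4 (0.28 log units; within the scatter) and a 1.7-fold higher number from compound 2 to compound 4 (0.24 log units; within the scatter) and a 1.9-fold higher number from compound 1 to compound 4 (0.27 log units; within the scatter) are the largest in the series so far, yet all remain unresolved from repeat variation. The position therefore accommodates 2,4-difluorophenyl as well as the three singly substituted aryl groups, with no established separation among the four compounds and no demonstrated effect of adding the second fluorine. No available evidence bears on the size of these steps.

Still open, from the compounds shown here alone, is whether an aryl group carrying a carboxylic acid or an amine, or a cyclohexyl group in place of the aryl group, would leave the numbers equally flat. Also open, going by these compounds, is whether a longer chain between the aryl group and the amine nitrogen in the ring would separate any compounds in this assay at all.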